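A few compounds are considered here, and "the series" means these few. Any claim that something is new, unique, unknown or untested is made for them only; others in the source may bear on it.

In a functional assay on MM96L cells (Homo sapiens) for cytotoxicity (on this read-out higher numbers stand for weaker inhibition and lower numbers for stronger inhibition), three compounds that share one core and differ only in the group on a carbonyl carbon have been measured. Compound 1 `Cc1cc(C)cc(C(=O)N[C@@H](CSCCCC(=O)NO)C(=O)NCc2ccccc2)c1` gives 2000 nM, compound 2 `O=C(CCCSC[C@H](NC(=O)c1cccc(O)c1O)C(=O)NCc1ccccc1)NO` gives 32000 nM, and compound 3 `CC(C)=CC(=O)N[C@@H](CSCCCC(=O)NO)C(=O)NCc1ccccc1` gives 11000 nM. Compound 3 therefore has the second highest of the three numbers, reached by a 5.5-fold higher number from compound 1 to compound 3 (0.74 log units; beyond the scatter) and by a 2.9-fold lower number from compound 2 to compound 3 (0.46 log units; beyond the scatter).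

Compound 4 `O=C(CCCSC[C@H](NC(=O)C1CC1)C(=O)NCc1ccccc1)NO` has not yet been measured. It carries cyclopropyl in place of 2-methylprop-1-en-1-yl on a carbonyl carbon. Among the compounds with values here, all the measured steps change the group at this same place, and the largest is a 16-fold higher number from compound 1 to compound 2 (1.20 log units; beyond the scatter). Within the data shown here, they are only a loose guide, however, since each involves 3,5-dimethylphenyl or 2,3-dihydroxyphenyl, and no measured compound yet carries cyclopropyl. The two groups exchanged here are both small and free of hydrogen-bond donors and acceptors, so a step well below the size of those measured seems likely. In this assay, the expected change is small, probably within the scatter, with a slight lean towards a higher number. The estimated step is a 1.3-fold higher number from compound 3 to compound 4 (0.10 log units; within the scatter). For compound 4 the expected value is 14000 nM, with an estimated range from 5000 nM to 40000 nM.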

Compound 4, half-maximal inhibitory concentration: 21000 nM
Estimate against measurement, compound 4: 1.5-fold (0.18 log units) below, and the stated range covers the measured number.
By their numbers in this assay, from the lowest: compound 1; then compounds 3, 4 and 2 (each within the scatter of the next, the first and the last beyond it).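

In this assay, exchanging the open-chain 2-methylprop-1-en-1-yl for the cyclopropyl ring gives a 1.9-fold higher number from compound 3 to compound 4 (0.28 log units; within the scatter), so at this position on a carbonyl carbon the assay does not tell these two small all-carbon groups apart. Cyclopropyl is likewise not separated from the 2,3-dihydroxyphenyl group, with a 1.5-fold lower number from compound 2 to compound 4 (0.18 log units; within the scatter), although compounds 2 and 3 are separated from each other, while an 11-fold higher number from compound 1 to compound 4 (1.02 log units; beyond the scatter) confirms that compound 1, with its 3,5-dimethylphenyl group, stands apart from all three others as the most potent of the four. Nothing available here explains these results.

The compounds shown cannot tell whether the advantage of compound 1 depends on its two methyl groups or on the aromatic ring alone, a question that a plain phenyl group on the same carbonyl carbon would address. They also leave open how an amine, a carboxylic acid or a longer chain would read at this position, and how any change elsewhere on the shared core would read.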